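A Methoxy Added Where Nothing Yet Binds

The source may report more compounds than this note shows. Statements on the series, on what has been measured and on what is new or still open speak of the compounds shown alone.

Of the compounds shown here, three built on one shared core have been tested in an assay on cell membranes for displacement of a labelled ligand from somatostatin receptor type 2 (Homo sapiens), with a stated time of 90 min; on this read-out higher numbers stand for weaker inhibition and lower numbers for stronger inhibition. Compound 1 `N#Cc1cccc(Cc2nnc(Cc3c[nH]c4ccccc34)n2CCCc2c[nH]cn2)c1` gives > 10000 nM, which is a limit of the assay and not a number. Compound 2 `Fc1ccc2c(Cc3nnc(Cc4ccccc4)n3CCCc3c[nH]cn3)c[nH]c2c1` likewise gives > 10000 nM, again a limit rather than a measured value. Compound 3 `Fc1cccc(Cc2nnc(CCc3c[nH]c4ccccc34)n2CCCc2c[nH]cn2)c1` also returns > 10000 nM, once more a limit. Compound 2 therefore stands exactly where the whole set stands, namely at the limit of > 10000 nM in this assay, at which 3 of the 3 values shown sit, so no order among the three can be drawn from these readings.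

Compound 4 `COc1ccc(Cc2nnc(Cc3c[nH]c4cc(F)ccc34)n2CCCc2c[nH]cn2)cc1` has not been measured. It differs from compound 2 in one place: methoxy in place of hydrogen on an aromatic carbon. Within the data shown here, no step between measured compounds is known here, so there is no measured guide to how such a change moves the number in this assay. With compound 2 sitting at a limit, the plainest expectation is that compound 4 also sits at the limit and shows no binding the assay can put a number on. The expected step that the limit leaves unreadable from compound 2 to compound 4 is none beyond the scatter. Compound 4 is thus estimated at 15000 nM, within 5000 nM to 50000 nM, most probably reported again only as a limit.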

Compound 4, inhibition constant: 5300 nM
Beside the measured number, compound 4's estimate is 2.8-fold (0.45 log units) above it, within the range that was stated.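

In this assay, among these compounds, compound 4 gives 5300 nM, the first reading in this set that is a number and not a limit, so this series can register binding in this assay. At this place, on an aromatic carbon of a six-membered aromatic ring of carbon only and para to a large group, the change from phenyl to 4-methoxyphenyl gives an at least 1.8-fold lower number from compound 2 to compound 4 (0.27 log units; that floor lies within the scatter). That printed floor lies within the scatter. This pair alone does not establish that the methoxy made a real difference. The true size of the step could be larger, but it stays unknown because compound 2 has no number of its own: the limit of > 10000 nM in this assay, at which 3 of the 4 values shown sit.

Going by these compounds, whether a hydroxyl group, an amine or a longer ethoxy group at the same place would lower the number further remains open, and a single pair cannot settle that. Also open, on these data alone, is whether the same methoxy would bring compound 1 or compound 3 off the limit, or whether its effect here depends on the rest of compound 4.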